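A few compounds are considered here, and "the series" means these few. Any claim that something is new, unique, unknown or untested is made for them only; others in the source may bear on it.

Compound 1, `Cc1nn(-c2ncnc3nc[nH]c23)c2c1C(OC1CCCC1)CC(=O)N2`, gives 2 nM in a functional assay on HEK293 cells for agonist activity at G-protein coupled receptor 39 (Homo sapiens), read by scintillation proximity assay and inositol phosphate accumulation, with a stated time of 75 min, in the presence of a further agent that is not named here; a higher number here means that more compound is needed for the effect, a lower number that less compound is needed.
Compound 2, `Cc1nn(-c2ncnc3nc[nH]c23)c2c1C(OCc1ccccc1C#N)CC(=O)N2`, gives 8 nM in this assay.
Compound 3, `Cc1nn(-c2ncnc3nc[nH]c23)c2c1C(C(=O)NCc1ccccc1)CC(=O)N2`, gives 5 nM in this assay.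

Among these three, compound 3 stands second highest. Its nearest neighbour is compound 2, and the step of a 1.6-fold lower number from compound 2 to compound 3 (0.20 log units; within the scatter) lies within the scatter, so those two values cannot be ordered. Its furthest neighbour is compound 1, and the step of a 2.5-fold higher number from compound 1 to compound 3 (0.40 log units; beyond the scatter) lies beyond the scatter.

Compound 4, `Cc1nn(-c2ncnc3nc[nH]c23)c2c1C(NC(=O)Cc1cccs1)CC(=O)N2`, differs from compound 3 in one place: (((thiophen-2-yl)methyl)carbonyl)amino in place of benzylcarbamoyl on a saturated ring carbon. Going by the values given here, no measured step makes this same exchange. The step of a 2.5-fold higher number from compound 1 to compound 3 (0.40 log units; beyond the scatter) put an amide on this saturated ring carbon in place of an ether and raised the number modestly, while the steps of a 4.0-fold higher number from compound 1 to compound 2 (0.60 log units; beyond the scatter) and a 1.6-fold lower number from compound 2 to compound 3 (0.20 log units; within the scatter) show that the changes tried at this position have kept the numbers within a narrow band. Compound 4 is therefore expected to remain in that band, with a step of a 1.8-fold higher number from compound 3 to compound 4 (0.26 log units; within the scatter) that may reach just beyond the scatter toward a higher number but need not. The estimate for compound 4 in this assay is 9 nM, between 2.5 nM and 35 nM.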

Compound 4, half-maximal effective concentration: 3 nM
For compound 4 the middle estimate is 3.0-fold (0.48 log units) above the measured one; low and high end bracket the measured number.
By their numbers in this assay, from the lowest: compounds 1, 4, 3 and 2 (each within the scatter of the next, the first and the last beyond it).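

Compound 4 shows that this saturated ring carbon also accepts an amide joined through its nitrogen, the (((thiophen-2-yl)methyl)carbonyl)amino group: in this assay the step of a 1.7-fold lower number from compound 3 to compound 4 (0.22 log units; within the scatter) and the step of a 1.5-fold higher number from compound 1 to compound 4 (0.18 log units; within the scatter) both lie within the scatter, so the data separate compound 4 from neither the benzylcarbamoyl nor the cyclopentyloxy compound. Going by these compounds alone, the one step beyond the scatter is a 2.7-fold lower number from compound 2 to compound 4 (0.43 log units; beyond the scatter) and it is modest, so compound 4 stands apart only from the (2-cyanobenzyl)oxy compound. Nothing at hand explains these differences.

On these data alone, it remains open how an amine or a carboxylic acid on this saturated ring carbon would read, and whether a longer chain in the amide would stay in the same narrow band. The effect of the thiophene ring also cannot be separated from that of the amide's direction, since compound 3 and compound 4 differ in both at once.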